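A few compounds are considered here, and "the series" means these few. Any claim that something is new, unique, unknown or untested is made for them only; others in the source may bear on it.

Among the compounds with values here, the step in view runs from compound 2 `CSc1nnc(-c2ccc(C)cc2)n1C` to the unmeasured compound 3 `Cc1ccc(-c2nnc([S+](C)[O-])n2C)cc1`, with compound 1 `Cn1c(-c2ccccc2)nnc1[S+](C)[O-]` as the only other measured member of the series. In a functional assay on the whole organism for antagonist activity, with Mus musculus as the target (a higher number here means that more compound is needed for the effect, a lower number that less compound is needed), compound 1 gives > 100 mg/kg as a limit and not a number. As far as these compounds go, compound 2 reads > 100 mg/kg in this assay, also a limit, so its exact position is unknown. The two measured compounds therefore share one boundary, (the limit of > 100 mg/kg in this assay, at which 2 of the 2 values shown sit), and no order between them can be read.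

Compound 3 differs from compound 2 at a single place, (a group of 3 heavy atoms (1 carbon, 1 oxygen, 1 sulfur; no ring) in place of a group of 2 heavy atoms (1 carbon, 1 sulfur; no ring), on an aromatic carbon), with the change lying between two ring nitrogen atoms. Within the data shown here, no measured step shows what this change does. The expectation starts from compound 2 at its limit of > 100 mg/kg and stays cautious, and another limit reading for compound 3 is quite possible. The estimated step of an at least 1.2-fold lower number from compound 2 to compound 3 (0.09 log units; that floor lies within the scatter) is small, towards less compound needed, and may not exceed the usual scatter. For compound 3 the expected dose is 80 mg/kg with an estimated range from 15 mg/kg to 200 mg/kg.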

Compound 3, dose for half-maximal effect: > 200 mg/kg
Compound 3: only a limit was reported; the forecaster's own chance of this, stated with the estimate: 55%; at least 2.5-fold (0.39 log units) between middle value and limit.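

In this assay compound 3 gives > 200 mg/kg, a limit and not a number. Within the data shown here, compound 1 and compound 2 also stand at limits, and no step from either of them to compound 3 can be read. The compounds shown leave open what replacing methylsulfanyl, or methyl in place of hydrogen, does to the dose.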